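Swapping the Dihydroxyphenyl Arm: Expected Effect on Growth Inhibition

This account rests on a few compounds, and the source may have more. Where it says the series, first, only, none or still open, it means among the compounds named here.

Three compounds were measured in a functional assay on cells (Cancer cell lines, Homo sapiens) for cytotoxicity, read by sulforhodamine B assay, with a stated time of 48 h; a higher number here means a weaker inhibitor of growth, a lower number a stronger inhibitor of growth. Compound 1 `NS(=O)(=O)c1ccc(-n2nc(-c3ccc(Cl)cc3)cc2-c2cc(O)ccc2O)cc1` gives 43100 nM. Compound 3 `NS(=O)(=O)c1ccc(-n2nc(-c3ccc(Cl)cc3)cc2C2=CC(=O)C=CC2=O)cc1` gives 37400 nM; the step of a 1.2-fold lower number from compound 1 to compound 3 (0.06 log units; within the scatter) corresponds to a group of 8 heavy atoms (6 carbon, 2 oxygen; one six-membered non-aromatic ring of carbon only) in place of a group of 8 heavy atoms (6 carbon, 2 oxygen; one six-membered aromatic ring of carbon only), on an aromatic carbon. Compound 2 `CC(=O)NS(=O)(=O)c1ccc(-n2nc(-c3ccccc3)cc2-c2cc(O)ccc2O)cc1` gives 100000 nM, the highest number of the three; how its core differs from that of compound 1 is not broken down here.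

Compound 4 `CC(=O)NS(=O)(=O)c1ccc(-n2nc(-c3ccccc3)cc2C2=CC(=O)C=CC2=O)cc1` has not yet been measured. It differs from compound 2 by a group of 8 heavy atoms (6 carbon, 2 oxygen; one six-membered non-aromatic ring of carbon only) in place of a group of 8 heavy atoms (6 carbon, 2 oxygen; one six-membered aromatic ring of carbon only), on an aromatic carbon. This is the same kind of change as that from compound 1 to compound 3, though the surroundings differ: in compound 2 the place is next to the ring atom that bears a large group and two ring bonds from the ring atom that bears a phenyl group, whereas in compound 1 it is next to the ring atom that bears a 4-sulfamoylphenyl group and two ring bonds from the ring atom that bears a 4-chlorophenyl group. Since the measured step of a 1.2-fold lower number from compound 1 to compound 3 (0.06 log units; within the scatter) lay within the scatter, a step of about the same size is expected, a 1.2-fold lower number from compound 2 to compound 4 (0.07 log units; within the scatter). Compound 4 is therefore estimated at 85000 nM, in a range from 40000 nM to 200000 nM.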

Compound 4, concentration for total growth inhibition: 100000 nM
The estimate for compound 4 lay 1.2-fold (0.07 log units) below the measured number; low and high end bracket the measured number.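

In this assay, putting the non-aromatic six-membered ring in place of the 2,5-dihydroxyphenyl group gave no change at the digits printed from compound 2 to compound 4 (within the scatter). Set beside the earlier step, the result shows that this swap behaved alike on the two cores: the same change on two cores in this assay, a 1.2-fold lower number (0.06 log units; within the scatter) from compound 1 to compound 3 and no change at the digits printed (within the scatter) from compound 2 to compound 4, 1.2-fold (0.06 log units) apart, within the scatter of two such steps This agreement covers only these two cores and does not show that the swap would leave the number flat on any other core, nor does it separate the contributions of the several features by which the two cores differ.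

The compounds shown leave open whether the step would stay this small if the phenyl group of compound 2 carried an amine or a carboxylic acid. They also leave open what would happen if a longer chain took the place of the phenyl group, since every compound here keeps an aromatic ring at that position.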